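The source may report more compounds than this note shows. Statements on the series, on what has been measured and on what is new or still open speak of the compounds shown alone.

Compound 1 `CCOC(=O)CCCCCOc1cccc(CN(C(=O)c2ccc(-c3cccc(N(C)C)c3)cc2)C(C)C)c1` was examined in an ADME assay on Raji cells (Homo sapiens) for cytotoxicity, read by CellTiter-Glo and resazurin assay, with a stated time of 72 h; a lower number here means that less compound is needed, a higher number that more compound is needed for the effect. In this assay compound 1 gives > 26000 nM, which is a limit of the assay and not a number, so compound 1 stands only at a boundary on the numbers shown. Its near relative compound 2 `CCOC(=O)CCCCCOc1cccc(CN(C(=O)c2ccc(-c3ccncc3)cc2)C(C)C)c1` was measured alongside it. In this assay compound 2 gives > 26000 nM, again a limit. What follows for the pair is a step that the two limits leave unreadable from compound 1 to compound 2; both values rest at the limit of > 26000 nM in this assay, at which 2 of the 2 values shown sit, and nothing about direction or size can be read from them.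

The compound not yet measured, compound 3 `CCOC(=O)CCCCCOc1cccc(CN(C(=O)c2ccc(-c3cccc(Oc4ccccc4)c3)cc2)C(C)C)c1`, differs from compound 1 by phenoxy in place of dimethylamino on an aromatic carbon. Among the compounds with values here, the single measured step that touches this position is unreadable, so it offers no direction for the new change. The expectation is that compound 3 will once more sit at the limit, and the step of a number no higher from compound 1 to compound 3 (the limit leaves the size open) is expected to be no larger than the scatter. For compound 3 the estimate in this assay is 26000 nM, with a range from 9000 nM to 80000 nM.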

Compound 3, half-maximal effective concentration: > 19600 nM
Compound 3 ended at the assay's limit (the forecaster's own chance of this, stated with the estimate: 80%); the middle value lies beyond the limit too.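

In this assay compound 3 gives > 19600 nM, which is a limit of the assay and not a number. Compound 1 and compound 3 both rest at limits, and the step between them cannot be read in direction or size. The compounds shown leave open whether changing this group alters cytotoxicity in any measurable way.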